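Chloro substitution on the amide aryl ring: growth inhibition notes

The source may hold more compounds than are shown below. What is called first, only, known or untested is meant among the compounds shown, and "the series" means these compounds.

Compound 1 `O=C(CCCCC(S)CCS)Nc1ccccn1` and compound 2 `O=C(CCCCC(S)CCS)Nc1ccc(Cl)cn1` share a core and differ by the change (chloro in place of hydrogen on an aromatic carbon). In a functional assay on KB cells (Homo sapiens) for inhibition, read by MTT assay, with a stated time of 24 h, tested at 100 ug/mL (on this read-out higher numbers stand for more inhibition of growth at the one concentration tested and lower numbers for less inhibition of growth), compound 1 gives 18.5% and compound 2 gives 76.6%; the step is a number 58.1 percentage points higher from compound 1 to compound 2 (beyond the scatter).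

Compound 3 `CC(=O)SCCC(CCCCC(=O)Nc1ccccc1)SC(C)=O` has a different core; the difference between its core and that of compound 1 is not broken down here. In this assay compound 3 gives 23%, which lies close to compound 1 and well apart from compound 2.

Compound 4 `CC(=O)SCCC(CCCCC(=O)Nc1ccccc1Cl)SC(C)=O` is not yet measured. It differs from compound 3 by chloro in place of hydrogen on an aromatic carbon. This is the same kind of change as from compound 1 to compound 2, but not the same: there the chloro sat on a six-membered aromatic ring with 1 nitrogen, two atoms from the ring nitrogen, para to a large group, whereas here it sits on a six-membered aromatic ring of carbon only, ortho to a large group. Because the step from compound 1 to compound 2 was a number 58.1 percentage points higher from compound 1 to compound 2 (beyond the scatter), a gain is expected for compound 4 in this assay, though smaller and less certain given the different core and place, estimated at a number 22 percentage points higher from compound 3 to compound 4 (beyond the scatter). Compound 4 is thus estimated at 45%, expected between 15% and 80%.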

Compound 4, percent growth inhibition at one concentration: 6.93%
The estimate for compound 4 lay 38.1 percentage points above the measured number; the measured number lies below the stated range.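

On the core of compound 3, chloro in place of hydrogen gives a number 16.1 percentage points lower from compound 3 to compound 4 (beyond the scatter) in this assay, so the gain seen on the core of compound 1 does not carry over and the sign of the step turns. These two steps do not separate the effect of the core from that of the place: the chloro of compound 4 sits on a ring of carbon only, ortho to a large group, while that of compound 2 sits elsewhere on a ring with 1 nitrogen, and one step per core gives no rule for either. The size or sign of this change therefore cannot be transferred from one core to the other in this series: the same change on two cores in this assay, a number 58.1 percentage points higher (beyond the scatter) from compound 1 to compound 2 and a number 16.1 percentage points lower (beyond the scatter) from compound 3 to compound 4, 74.2 percentage points apart, beyond the scatter of two such steps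

The compounds shown leave open whether the chloro at another place on the ring of compound 3 would follow compound 2 or compound 4. Also open, on these data alone, is how a fluoro, methoxy or bromo group at the same place would compare on either core.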